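Reversing the Stereocentre of Compound 1

The compounds below may be only part of what the source reports. "The series", "measured", "known", "first", "only" and "open" are said of these compounds alone.

Within the data shown here, in a physicochemical assay for lipophilicity, read by HPLC, measured as chromatographic lipophilicity, at pH 7.4 (on this read-out lower numbers stand for lower lipophilicity and higher numbers for higher lipophilicity), compound 1 (`CNC(=O)c1cc(C(=O)NC2CC2)cn([C@H](C)c2ccccc2)c1=O`) gives 3.5 and stands highest of the two numbers so far, while compound 2 (`CNC(=O)c1cc(C(=O)NC2CC2)cn(Cc2cccc3[nH]ccc23)c1=O`) gives 2.9 and lies lower by more than the scatter. Compound 3 (`CNC(=O)c1cc(C(=O)NC2CC2)cn([C@@H](C)c2ccccc2)c1=O`) departs from compound 1 in configuration only (the two compounds have the same atoms and bonds and differ only in configuration as drawn: 1 of 1 stereo elements differ; a stereocentre at a saturated chain carbon is drawn R in compound 1 and S in compound 3). Among the measured compounds shown here, no measured pair yet shows such a change. No step beyond the scatter is expected in this assay in either direction. The estimated step is no change at the digits printed from compound 1 to compound 3 (within the scatter) and stays within the scatter. For compound 3 the expected value is 3.5 with a range from 3.2 to 3.8 in this estimate.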

Compound 3, distribution coefficient: 3.3
Estimate against measurement, compound 3: 0.20 log units above; the range from low to high includes it.
By their numbers in this assay, from the lowest: compound 2; then compounds 3 and 1 (each within the scatter of the next).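

Reversing the stereocentre at the saturated chain carbon gives a number 0.20 log units lower from compound 1 to compound 3 (within the scatter) in this assay. Among these compounds, this is the first measured pair to test configuration at this position, and on this read-out the two forms are not told apart. The pair isolates that single change: the fact that compounds 1 and 3 differ only in the configuration as drawn.

Going by these compounds, whether the two configurations would still read alike with a longer chain or a carboxylic acid at this stereocentre stays open. So does whether they would also read alike in any read-out other than this assay.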